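Swapping an anilino group for piperidine on the quinone carbon

The source may report more compounds than this note shows. Statements on the series, on what has been measured and on what is new or still open speak of the compounds shown alone.

Of the compounds shown here, two of a shared core have been measured in a functional assay on ECa-109 cells for inhibition, with ECa-109 cell line (Homo sapiens) as the target, read by sulforhodamine B assay; on this read-out lower numbers stand for stronger inhibition and higher numbers for weaker inhibition. Compound 1 `Cc1ccc(NC2=CC(=O)c3nc4n(c3C2=O)[C@H]2OC[C@@H](O)[C@H]2OC4)cc1` gives 3480 nM in this assay. Compound 2 `O=C1C(Nc2ccccc2)=CC(=O)c2c1nc1n2[C@H]2OC[C@@H](O)[C@H]2OC1` gives 3560 nM in this assay, and the two numbers lie within the usual scatter of each other, so neither compound can be set apart from the other on this read-out. Compound 3 `O=C1C=C(N2CCCCC2)C(=O)c2c1nc1n2[C@H]2OC[C@@H](O)[C@H]2OC1` has not yet been measured. It differs from compound 1 in one place: piperidin-1-yl in place of (4-methylphenyl)amino on a double-bonded ring carbon. Going by the values given here, no measured pair shows what such a change does here, since compound 1 and compound 2 differ only on the aromatic ring that leaves. With the hydrogen-bond donor gone and the aromatic ring replaced by the saturated ring, a step somewhat beyond the scatter toward weaker inhibition is expected, though with little certainty. For compound 3 the expected step is a 1.9-fold higher number from compound 1 to compound 3 (0.27 log units; within the scatter), and its estimated value in this assay is 6500 nM, likely between 2000 nM and 20000 nM.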

Compound 3, half-maximal inhibitory concentration: > 8000 nM
Compound 3: no number, only a limit (the forecaster's own chance of this, stated with the estimate: 10%); middle value at least 1.2-fold (0.09 log units) away from the limit.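

In this assay, compound 3 carries only a limit and not a number: the limit of > 8000 nM in this assay, at which 1 of the 3 values shown sits.

Even so, the change on the double-bonded ring carbon can be read, as piperidin-1-yl in place of (4-methylphenyl)amino gives an at least 2.2-fold higher number from compound 1 to compound 3 (0.36 log units; beyond the scatter). Going by these compounds alone, compound 1 and compound 2 differ only on the aromatic ring and lie within the usual scatter of each other, so this is the first sign that inhibition responds to what stands at this position.

The step replaces the aromatic ring with a non-aromatic one and removes the hydrogen-bond donor together, and the compounds shown do not separate the two. On these data alone, whether a cyclohexylamino group, with its saturated ring and its amine hydrogen, would stay close to compound 1 remains open.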